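From the side chain of compound 3 to compound 4

This account rests on a few compounds, and the source may have more. Where it says the series, first, only, none or still open, it means among the compounds named here.

Values in a functional assay on MCF7 cells (Homo sapiens) for antiproliferative activity, read by MTT assay, with a stated time of 24 h; on this read-out lower numbers stand for stronger inhibition and higher numbers for weaker inhibition:
Compound 1 `CCn1c(C(=O)N[C@@H](C)C(=O)OC)ccc1C(CC)(CC)c1ccc(OCS(=O)(=O)c2ccccc2)c(C)c1`: 43700 nM
Compound 2 `CCn1c(C(=O)NCC(=O)OC)ccc1C(CC)(CC)c1ccc(OCS(=O)(=O)c2ccccc2)c(C)c1`: > 50000 nM
Compound 3 `CCn1c(C(=O)NCCNC(=O)OC(C)(C)C)ccc1C(CC)(CC)c1ccc(OCS(=O)(=O)c2ccccc2)c(C)c1`: > 50000 nM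

Compound 3 gives > 50000 nM, which is a limit of the assay and not a number. Compound 2 gives > 50000 nM, which is also a limit. Compound 3 therefore stands at the limit of > 50000 nM in this assay, at which 2 of the 3 values shown sit. Only compound 1, at 43700 nM, has a true number.

Compound 4 `CCn1c(C(=O)N[C@@H](C)CO)ccc1C(CC)(CC)c1ccc(OCS(=O)(=O)c2ccccc2)c(C)c1` changes one substituent of compound 3: 1-(hydroxymethyl)ethyl in place of 2-((tert-butoxycarbonyl)amino)ethyl on an amide-type nitrogen. In words, 1-(hydroxymethyl)ethyl takes the place of 2-((tert-butoxycarbonyl)amino)ethyl on an amide-type nitrogen.

The closest measured change at this place is an at least 1.1-fold higher number from compound 1 to compound 3 (0.05 log units; that floor lies within the scatter). A second change on the same side chain is an at least 1.1-fold higher number from compound 1 to compound 2 (0.05 log units; that floor lies within the scatter). The remaining one, a step that the two limits leave unreadable from compound 2 to compound 3, gives no size at all.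

None of these three steps shows a change beyond the scatter, so no step beyond the scatter is expected in this assay. The expected step is an at least 1.0-fold lower number from compound 3 to compound 4 (0.01 log units; that floor lies within the scatter). For compound 4 the estimate is 48000 nM, with an expected range of 20000 nM to 80000 nM.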

Compound 4, half-maximal inhibitory concentration: 10800 nM
Compound 4: middle estimate off by 4.4-fold (0.65 log units), on the high side, and the stated range ends above it.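

In this assay, hydroxymethyl in place of methoxycarbonyl gives a 4.0-fold lower number from compound 1 to compound 4 (0.61 log units; beyond the scatter). Within the data shown here, this is a single change on the side chain at the amide-type nitrogen, and it is the first step at this position that lies beyond the scatter with a true number at both ends. The steps to compound 4 from the other two compounds, an at least 4.6-fold lower number from compound 3 to compound 4 (0.66 log units; beyond the scatter) and an at least 4.6-fold lower number from compound 2 to compound 4 (0.66 log units; beyond the scatter), also lie beyond the scatter, but they are only floors, as compound 2 and compound 3 each sit at a limit of the assay: the limit of > 50000 nM in this assay, at which 2 of the 4 values shown sit.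

The compounds shown leave open whether hydroxymethyl itself matters, which an amine, a carboxylic acid or a longer chain ending in a hydroxyl group in its place could test. Equally open, as far as these compounds go, is whether the opposite stereocentre in 1-(hydroxymethyl)ethyl would give the same number.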